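Phenol for Propylphenyl on a Sulfonate Ester

This account rests on a few compounds, and the source may have more. Where it says the series, first, only, none or still open, it means among the compounds named here.

Compound 1, `CCCc1ccccc1OS(=O)(=O)c1cccc(NC(=O)NCCCCl)c1`: 14000 nM
Compound 2, `O=C(NCCCCl)Nc1cccc(S(=O)(=O)Oc2ccc(O)cc2)c1`: 51000 nM
Compound 3, `CCCc1ccccc1OS(=O)(=O)c1ccc(NC(=O)NCCCCl)cc1`: 15000 nM

These three compounds were tested in a functional assay on MCF7 cells (Homo sapiens) for cytotoxicity, read by sulforhodamine B assay, with a stated time of 48 h; on this read-out higher numbers stand for weaker inhibition and lower numbers for stronger inhibition. Compound 1 and compound 3 are built from the same atoms joined differently; the difference between the two cores is not broken down here, and in this assay their values lie within the scatter of each other. Compound 2 carries 4-hydroxyphenyl in place of 2-propylphenyl on an oxygen relative to compound 1, and that change gave a 3.6-fold higher number from compound 1 to compound 2 (0.56 log units; beyond the scatter). Compound 4, `O=C(NCCCCl)Nc1ccc(S(=O)(=O)Oc2ccc(O)cc2)cc1`, has not yet been measured. It stands to compound 3 as compound 2 stands to compound 1, with 4-hydroxyphenyl in place of 2-propylphenyl on an oxygen, the same change at the same place. Among the measured compounds shown here, a step of similar size is expected for compound 4, namely a 3.3-fold higher number from compound 3 to compound 4 (0.52 log units; beyond the scatter), because a 3.6-fold higher number from compound 1 to compound 2 (0.56 log units; beyond the scatter) was seen for the one earlier example of this change. Compound 4 is therefore estimated at about 50000 nM, expected to fall between 25000 nM and 100000 nM.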

Compound 4, half-maximal inhibitory concentration: 51000 nM
Estimate against measurement, compound 4: 1.0-fold (0.01 log units) below, within the range that was stated.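

In this assay the swap of 2-propylphenyl for 4-hydroxyphenyl on an oxygen gave a 3.4-fold higher number from compound 3 to compound 4 (0.53 log units; beyond the scatter) on the second core, so the change carried across with its size kept: the same change on two cores in this assay, a 3.6-fold higher number (0.56 log units; beyond the scatter) from compound 1 to compound 2 and a 3.4-fold higher number (0.53 log units; beyond the scatter) from compound 3 to compound 4, 1.1-fold (0.03 log units) apart, within the scatter of two such steps. Among the compounds shown here, this rests on only two pairs, on two cores built from the same kinds of parts, read in one assay. It therefore gives no rule for other cores in the series and does not show what in the change produces the step. The compounds shown leave open how an amine or a carboxylic acid on the phenyl ring would read on either core. They also leave open what a longer chain in place of the propyl would do.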